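The source may hold more compounds than are shown below. What is called first, only, known or untested is meant among the compounds shown, and "the series" means these compounds.

Measured compounds:
- compound 1, `CCOC(=O)C1=C(Nc2ccc(Br)cc2)C(=O)N(c2ccc(Br)cc2)C1` — 1.75
- compound 2, `CCOC(=O)C1=C(Nc2ccc(Br)cc2)C(=O)N(C2CCCCC2)C1c1ccccc1` — 2.25

In a physicochemical assay for lipophilicity, using the shake flask method, measured as octanol-water partition (a higher number here means a more lipophilic compound, a lower number a more polar compound), compound 1 gives 1.75. In this assay compound 2 gives 2.25, the higher of the two numbers, and the gap between the two lies beyond the usual scatter of this measurement. No single-point comparison between these two compounds is available, as they differ in more than one place, so their values can only be set side by side.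

Compound 3, `CCOC(=O)C1=C(Nc2cccc3ccccc23)C(=O)N(C2CCCCC2)C1c1ccccc1`, has not yet been measured in this assay. It differs from compound 2 in one place: naphthalen-1-yl in place of 4-bromophenyl on an amine nitrogen. Among the measured compounds shown here, only two numbers are known here, and neither of them isolates this particular change, so the step has to be estimated rather than read from a measured pair. Compound 3 is expected to come out somewhat higher than compound 2, with a step from compound 2 to compound 3 of about a number 0.35 log units higher from compound 2 to compound 3 (beyond the scatter). For compound 3 the estimated value in this assay is 2.6, with a range from 2 to 3.2.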

Compound 3, partition coefficient: 2
Compound 3: middle estimate off by 0.60 log units, on the high side; low and high end bracket the measured number.
By their numbers in this assay, from the lowest: compounds 1, 3 and 2 (each within the scatter of the next, the first and the last beyond it).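

In this assay, among the compounds shown here, putting naphthalen-1-yl in place of 4-bromophenyl on an amine nitrogen gives a number 0.25 log units lower from compound 2 to compound 3 (within the scatter), and this is the first comparison in the set in which only one place changes. The entering group has 10 heavy atoms, all carbon, and two six-membered aromatic rings, whereas the leaving group has 7 heavy atoms, including a bromine, and one such ring, yet this measurement cannot tell compound 2 and compound 3 apart. Nothing available bears on why these two groups read alike at this position.

As far as these compounds go, the two aryl groups compared here say little about very different groups on the same amine nitrogen, such as an unsubstituted phenyl, a pyridine ring, or a phenyl ring carrying a carboxylic acid or an amine, so whether any of these would shift the number beyond the scatter remains open. Compound 1 and compound 2 still differ in more than one place, so the share of each difference in the gap between their values cannot be read.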